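The source may report more compounds than this note shows. Statements on the series, on what has been measured and on what is new or still open speak of the compounds shown alone.

In an in vitro functional assay on 1321-N1 cells for agonist activity at Free fatty acid receptor 1 (Homo sapiens), read by fluorescence (a lower number here means that less compound is needed, a higher number that more compound is needed for the effect), compound 1 `O=Cc1cccc(C#Cc2ccc(CCC(=O)O)cc2)c1` gives 355 nM, the lower of the two numbers in hand. Compound 2 `O=C(O)COc1ccc(C#Cc2ccccc2)cc1` gives 1260 nM in this assay, a gap beyond the usual scatter, though the two differ in several places. Compound 3 `Nc1cccc(C#Cc2ccc(CCC(=O)O)cc2)c1` is the next point, made from compound 1 by amino in place of formyl on an aromatic carbon. Within the data shown here, no measured pair isolates this change, so the expected step from compound 1 to compound 3 in this assay, a 1.8-fold higher number from compound 1 to compound 3 (0.26 log units; within the scatter), is a modest rise, roughly at the edge of the scatter. Compound 3 is thus estimated at 650 nM, within 200 nM to 2000 nM.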

Compound 3, half-maximal effective concentration: 1100 nM
Compound 3: the middle estimate sits 1.7-fold (0.23 log units) below what was measured; low and high end bracket the measured number.
By their numbers in this assay, from the lowest: compound 1; then compounds 3 and 2 (each within the scatter of the next).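

Among these compounds, the aromatic carbon meta to a large group is sensitive to what it carries: amino in place of formyl gives a 3.1-fold higher number from compound 1 to compound 3 (0.49 log units; beyond the scatter) in this assay and is the first change read at this position. The swap replaces formyl, with two heavy atoms and no hydrogen-bond donor, by amino, with one heavy atom and one donor, and this single pair cannot separate those differences. Nothing at hand explains the step.

From the compounds shown here alone, whether a nitrile, a hydroxymethyl or a carboxylic acid on this carbon would match formyl remains open. Compound 2 differs from the others in several places and gives no reading on this position.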